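This account rests on a few compounds, and the source may have more. Where it says the series, first, only, none or still open, it means among the compounds named here.

Compound 2 `O=S(=O)(c1cccc(Cl)c1)N1CCOc2c(N3CCNCC3)cccc21` carries a 3-chlorophenyl group on its sulfonyl sulfur, and in an assay on HEK293 cells for displacement of a labelled ligand from 5-hydroxytryptamine receptor 6 (Homo sapiens) (on this read-out higher numbers stand for weaker inhibition and lower numbers for stronger inhibition), compound 2 gives 2 nM. Its one companion, compound 1 `O=S(=O)(c1ccccc1Cl)N1CCOc2c(N3CCNCC3)cccc21`, differs only in bearing a 2-chlorophenyl group there; in this assay compound 1 gives 3.16 nM. The two sit within the scatter of each other, the change being a 1.6-fold lower number from compound 1 to compound 2 (0.20 log units; within the scatter), so neither can be called the stronger binder.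

Compound 3 `O=S(=O)(c1cccc(F)c1)N1CCOc2c(N3CCNCC3)cccc21` is the next step from compound 2: fluoro in place of chloro on an aromatic carbon, which is fluoro in place of chloro on an aromatic carbon. For the measured compounds named here, no measured pair shows a halogen swapped for another halogen; the only step on hand concerns where the chloro sits, and that step was within the scatter. What the two values do show is that this part of the molecule tolerated one small alteration without a clear shift.

On that basis the expectation for compound 3 is a step of a 1.8-fold higher number from compound 2 to compound 3 (0.24 log units; within the scatter), with no clear direction beyond the scatter. Compound 3 is therefore estimated at 3.5 nM in this assay, with a plausible range from 1.5 nM to 8 nM.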

Compound 3, inhibition constant: 10 nM
Compound 3: middle estimate off by 2.9-fold (0.46 log units), on the low side; the measured number lies above the stated range.
By their numbers in this assay, from the lowest: compounds 2 and 1 (each within the scatter of the next); then compound 3.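

Moving the chloro had left the number within the scatter, but exchanging the halogen at this position does not: in this assay the change gives a 5.0-fold higher number from compound 2 to compound 3 (0.70 log units; beyond the scatter) and so counts as a real, if modest, loss of binding strength. Set against the other chloro compound there is a 3.2-fold higher number from compound 1 to compound 3 (0.50 log units; beyond the scatter) as well, so compound 3 is the weakest of the three, and among these compounds the identity of the halogen counts for more than where the chloro sits. Nothing available here explains why replacing one halogen atom with another should shift the result.

On these data alone, it remains open whether the trend among the halogens extends to bromo, which would show if a heavier halogen holds or improves the number, and how a plain phenyl group with no halogen at all would compare. Equally open, as far as these compounds go, is whether this position accepts groups that are not halogens, such as a methyl, a methoxy or a nitrile, and whether fluoro would read the same at another place on the ring.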